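The compounds below may be only part of what the source reports. "The series", "measured", "known", "first", "only" and "open" are said of these compounds alone.

Measured in a functional assay on HeLa cells (Homo sapiens) for antiproliferative activity, read by MTT assay, with a stated time of 48 h; a lower number here means a stronger inhibitor, a higher number a weaker inhibitor:
- compound 1 `Brc1cccc(CSc2nnc(-c3cnccn3)o2)c1`: 30300 nM
- compound 2 `Clc1ccc(CSc2nnc(-c3cnccn3)o2)cc1`: 24600 nM
- compound 3 `Clc1cccc(CSc2nnc(-c3cnccn3)n2-c2ccccc2)c1`: 13500 nM

Compound 3 at 13500 nM and compound 2 at 24600 nM lie within the usual scatter of each other. Compound 1 alone lies beyond the scatter from compound 3, with a higher number.

Compound 4 `Fc1cccc(F)c1CSc1nnc(-c2cnccn2)n1-c1ccccc1` keeps the core of compound 3 and differs by 2,6-difluorophenyl in place of 3-chlorophenyl on a saturated chain carbon bound to a sulfur.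

Among the compounds with values here, no two measured compounds differ in one place only, so nothing here sizes this change directly. In this assay, no step beyond the scatter is expected. The estimated 1.1-fold higher number from compound 3 to compound 4 (0.05 log units; within the scatter) is therefore small. For compound 4, the expected value is 15000 nM, with an estimated range of 6000 nM to 38000 nM.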

Compound 4, half-maximal inhibitory concentration: > 50000 nM
Compound 4: a limit, no number; the forecaster's own chance of this, stated with the estimate: 7%; middle value at least 3.3-fold (0.52 log units) from the limit.
By their numbers in this assay, from the lowest: compounds 3, 2 and 1 (each within the scatter of the next, the first and the last beyond it). At a limit, above all of these: compound 4.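

Within the data shown here, on a saturated chain carbon bound to a sulfur, the result shows for the first time that the ring carried there matters: in this assay, 2,6-difluorophenyl in place of 3-chlorophenyl gives an at least 3.7-fold higher number from compound 3 to compound 4 (0.56 log units; beyond the scatter). Compound 4 reads > 50000 nM, which is a limit of the assay and not a number, so the full size of this step remains unknown: the limit of > 50000 nM in this assay, at which 1 of the 4 values shown sits.

On these data alone, whether a pyridine ring or a cyclohexyl group at this place would retain the value of compound 3 stays open. As far as these compounds go, a longer chain between the sulfur and the ring is equally open.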